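This account rests on a few compounds, and the source may have more. Where it says the series, first, only, none or still open, it means among the compounds named here.

Working notes on the urea series.

Compound 1 `CC(C)c1cccc(C(C)C)c1NC(=O)Nc1ccccc1` is the unsubstituted parent; in an assay on isolated protein for inhibition of acyl-CoA:cholesterol acyltransferase (Oryctolagus cuniculus) (a lower number here means a stronger inhibitor, a higher number a weaker inhibitor), compound 1 gives 910 nM. Compound 2 `CCCc1ccc(NC(=O)Nc2c(C(C)C)cccc2C(C)C)cc1` carries a propyl group on the distal aromatic ring; in this assay compound 2 gives 38 nM. For the measured compounds named here, the only step between measured compounds is a 24-fold lower number from compound 1 to compound 2 (1.38 log units; beyond the scatter), a large move. On the numbers shown, compound 2 stands lowest of the two; its nearest neighbour is compound 1, separated by that same step.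

The next compound, compound 3 `CCCCCCCc1ccc(NC(=O)Nc2c(C(C)C)cccc2C(C)C)cc1`, extends the chain: butyl in place of hydrogen on a saturated chain carbon, three bonds along the chain from an aromatic carbon. Going by the values given here, the single step that bears on this is the propyl-for-hydrogen change, which moved this assay by a 24-fold lower number from compound 1 to compound 2 (1.38 log units; beyond the scatter). On these data alone, that step shows that a longer chain on that ring went with a markedly lower number; whether the gain continues past propyl is untested, so a further drop is expected, but a smaller one. For compound 3 the estimate is a step of a 2.5-fold lower number from compound 2 to compound 3 (0.40 log units; beyond the scatter) because of a 24-fold lower number from compound 1 to compound 2 (1.38 log units; beyond the scatter). Compound 3 is expected to give 15 nM in this assay, within a range of 5 nM to 45 nM.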

Compound 3, half-maximal inhibitory concentration: 19 nM
For compound 3 the middle estimate is 1.3-fold (0.10 log units) below the measured one, within the range that was stated.
By their numbers in this assay, from the lowest: compounds 3 and 2 (each within the scatter of the next); then compound 1.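

Working from the heptyl chain, the added butyl gives a 2.0-fold lower number from compound 2 to compound 3 (0.30 log units; within the scatter) in this assay and so separates compound 3 from compound 2 by no more than repeat measurements would. The large shift from the unsubstituted parent is kept with the longer chain, at a 48-fold lower number from compound 1 to compound 3 (1.68 log units; beyond the scatter) in this assay, so this position accepts heptyl as well as propyl, and the extra length adds no readable gain over propyl. The measured data offer no explanation for either step.

The compounds shown leave open whether an ethyl or butyl group in place of hydrogen on that aromatic carbon already reaches the level of compound 2, and whether a chain longer than heptyl, such as dodecyl, holds that level or lets the number rise. They also leave open whether that position accepts anything other than a plain carbon chain, such as a carboxylic acid or an amine in place of the heptyl group.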